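A Halogen Pair in Place of Chloro and Nitro

The source may report more compounds than this note shows. Statements on the series, on what has been measured and on what is new or still open speak of the compounds shown alone.

In a functional assay on MDA-MB-231 cells (Homo sapiens) for cytotoxicity, read by MTT assay, with a stated time of 48 h (a lower number here means a stronger inhibitor, a higher number a weaker inhibitor), compound 1 (`Nc1ccc(NC(=O)NCCCCC(c2ccc(F)cc2)c2ccc(F)cc2)cc1`) gives > 20000 nM, which is a limit of the assay and not a number. Within the data shown here, compound 2 (`O=C(NCCCCC(c1ccc(F)cc1)c1ccc(F)cc1)Nc1ccc(Cl)c([N+](=O)[O-])c1`) gives 4060 nM, the only actual number so far. Among the measured compounds shown here, the one measured step is an at least 4.9-fold lower number from compound 1 to compound 2 (0.69 log units; beyond the scatter), with 4-chloro-3-nitrophenyl in place of 4-aminophenyl on an amide-type nitrogen. Its size is only a bound, resting on (the limit of > 20000 nM in this assay, at which 1 of the 2 values shown sits). Compound 3 (`O=C(NCCCCC(c1ccc(F)cc1)c1ccc(F)cc1)Nc1ccc(Br)cc1I`) changes the same place, with 4-bromo-2-iodophenyl in place of 4-chloro-3-nitrophenyl on an amide-type nitrogen. That measured step shows that the group on this nitrogen can move the number, but it does not involve the entering group and gives no firm direction. Compound 2, at 4060 nM, is therefore the best anchor. The expected change is small, a 1.2-fold higher number from compound 2 to compound 3 (0.09 log units; within the scatter), with no shift beyond the scatter anticipated. Compound 3 is estimated at 5000 nM, with an expected range from 1800 nM to 15000 nM.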

Compound 3, half-maximal inhibitory concentration: > 20000 nM
Compound 3: a limit, no number (the forecaster's own chance of this, stated with the estimate: 15%); at least 4.0-fold (0.60 log units) between middle value and limit.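

In this assay, among these compounds, placing 4-bromo-2-iodophenyl on this amide-type nitrogen gives an at least 4.9-fold higher number from compound 2 to compound 3 (0.69 log units; beyond the scatter), which shows that this pair of halogens does not stand in for chloro and nitro, and that 4-chloro-3-nitrophenyl remains the only group here with a measured number. Compound 3 gives > 20000 nM, which is a limit of the assay and not a number. The step from compound 2 is therefore only a bound, and the step from compound 1 to compound 3 cannot be read, since both ends are limits: the limit of > 20000 nM in this assay, at which 2 of the 3 values shown sit.

The compounds shown do not separate the contribution of the chlorine from that of the nitro group, so 4-chlorophenyl and 3-nitrophenyl remain open. Also open, as far as these compounds go, is whether 4-bromophenyl, without the iodine, would give a number in this assay.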